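The compounds below may be only part of what the source reports. "The series", "measured", "known", "first", "only" and "open" are said of these compounds alone.

Of the compounds shown here, three built on a shared core have been measured in a functional assay on MCF7 cells (Homo sapiens) for cytotoxicity, read by MTT assay, with a stated time of 24 h; on this read-out lower numbers stand for stronger inhibition and higher numbers for weaker inhibition. Compound 1 `CC1=C([Se]CC(OC(=O)[C@@H](CSSC(C)(C)C)NC(=O)OC(C)(C)C)C(=O)NC(C)(C)C)C(=O)c2ccccc2C1=O` gives 3000 nM in this assay. Compound 2 `CC1=C(SCCC(=O)OC(C[Se]c2ccccc2)C(=O)NCCCCCC(=O)OCc2ccccc2)C(=O)c2ccccc2C1=O` gives 10000 nM, and compound 3 `CC1=C(SCCC(=O)OC(C[Se]C2=C(C)C(=O)c3ccccc3C2=O)C(=O)NCCCCCC(=O)OCc2ccccc2)C(=O)c2ccccc2C1=O` gives 10000 nM. Compound 2 and compound 3 stand level at the digits shown, within the scatter of each other, and together they carry the highest numbers of the set, while compound 1 shows a lower number than compound 2 by a gap that lies beyond the scatter.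

The untested compound 4 `CC1=C(SCCC(=O)OC(CC[Se]c2ccccc2)C(=O)NCCCCCC(=O)OCc2ccccc2)C(=O)c2ccccc2C1=O` differs from compound 2 in one place: a group of 8 heavy atoms (7 carbon, 1 selenium; one six-membered aromatic ring of carbon only) in place of a group of 7 heavy atoms (6 carbon, 1 selenium; one six-membered aromatic ring of carbon only), on a saturated chain carbon, two bonds along the chain from a carbonyl carbon and an oxygen next to a carbonyl group. For the measured compounds named here, no pair of measured compounds differs by this kind of change alone, so there is no measured step to lean on. The change is a modest lengthening of a chain, and since compound 2 at 10000 nM and compound 3 at 10000 nM sit level despite a larger difference in that same region, the step from compound 2 to compound 4 is expected to be small, no change at the digits printed from compound 2 to compound 4 (within the scatter), with no direction beyond the scatter. Compound 4 is accordingly estimated at 10000 nM, with a range from 4000 nM to 25000 nM.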

Compound 4, half-maximal inhibitory concentration: 19000 nM
Compound 4: the middle estimate sits 1.9-fold (0.28 log units) below what was measured, and the stated range covers the measured number.
By their numbers in this assay, from the lowest: compound 1; then compounds 2, 3 and 4 (each within the scatter of the next).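

In this assay the result is a 1.9-fold higher number from compound 2 to compound 4 (0.28 log units; within the scatter) on putting the group of 8 heavy atoms (7 carbon, 1 selenium; one six-membered aromatic ring of carbon only) in place of the group of 7 heavy atoms (6 carbon, 1 selenium; one six-membered aromatic ring of carbon only). For the compounds shown here, this is the first measured step at this position, on a saturated chain carbon, and it shows that this change taken alone does not carry the read-out beyond the scatter. Nothing available accounts for the step.

The compounds shown leave open whether a longer chain at this position, or an amine or a carboxylic acid at the end of it, would shift the number beyond the scatter. Also open, as far as these compounds go, is whether the same change would read alike on compound 3.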